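A few compounds are considered here, and "the series" means these few. Any claim that something is new, unique, unknown or untested is made for them only; others in the source may bear on it.

Measured compounds in an assay on kidney for inhibition of Neprilysin (Rattus norvegicus); on this read-out lower numbers stand for stronger inhibition and higher numbers for weaker inhibition: compound 1 `O=C1NC(C(=O)Nc2ccccc2)CCCCCCC1CS` gives 551 nM; compound 2 `O=C1NC(C(=O)N[C@H](CO)C(=O)O)CCCCCCC1CS` gives 11 nM; compound 3 `O=C1NC(C(=O)NCCOCCO)CCCCCCC1CS` gives 84 nM.

Compound 1 stands at the highest number of the three; its nearest neighbour is compound 3 and its furthest compound 2.

Compound 4 `CS(=O)(=O)CCCNC(=O)C1CCCCCCC(CS)C(=O)N1` has not been measured. Relative to compound 1 the change is 3-(methylsulfonyl)propyl in place of phenyl on an amide-type nitrogen.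

Going by the values given here, two measured steps bear on this, both replacing the same phenyl on the amide-type nitrogen with an open chain: a 50-fold lower number from compound 1 to compound 2 (1.70 log units; beyond the scatter) and a 6.6-fold lower number from compound 1 to compound 3 (0.82 log units; beyond the scatter). Among the compounds with values here, both replacements gave a lower number, and no measured compound goes against that. The gap between the two chains is a 7.6-fold higher number from compound 2 to compound 3 (0.88 log units; beyond the scatter); the chain entering in compound 4 carries neither a carboxy group nor a hydroxy group, so the smaller of the two steps is the closer guide. The step from compound 1 to compound 4 is therefore expected to be a 4.6-fold lower number from compound 1 to compound 4 (0.66 log units; beyond the scatter), a lower number, beyond the scatter. For compound 4 the estimate in this assay is 120 nM, with a range from 40 nM to 400 nM.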

Compound 4, half-maximal inhibitory concentration: 63 nM
Estimate against measurement, compound 4: 1.9-fold (0.28 log units) above; the measured number falls inside the stated range.
By their numbers in this assay, from the lowest: compound 2; then compounds 4 and 3 (each within the scatter of the next); then compound 1.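

In this assay, the open chain on the amide-type nitrogen need not carry a hydroxy or carboxy group for the number to fall: 3-(methylsulfonyl)propyl, with 0 hydrogen-bond donors, gives an 8.7-fold lower number from compound 1 to compound 4 (0.94 log units; beyond the scatter). Exchanging 2-hydroxyethoxy for (methylsulfonyl)methyl on the chain gives a 1.3-fold lower number from compound 3 to compound 4 (0.12 log units; within the scatter), so these two chains are not separated within the scatter. The 1-carboxy-2-hydroxyethyl group remains apart from the sulfone chain, with a 5.7-fold higher number from compound 2 to compound 4 (0.76 log units; beyond the scatter).

Still open, from the compounds shown here alone, is whether a plain butyl chain or a chain ending in an amine would give a similar step from compound 1, and how a carboxylic acid without the hydroxy group would compare with compound 2. No available evidence accounts for these differences.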